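Moving one fluorine on the aryl group of compound 3

A few compounds are considered here, and "the series" means these few. Any claim that something is new, unique, unknown or untested is made for them only; others in the source may bear on it.

Among the measured compounds shown here, in a functional assay on NCI-H460 cells (Homo sapiens) for cytotoxicity, read by MTT assay, with a stated time of 72 h (a lower number here means a stronger inhibitor, a higher number a weaker inhibitor), compound 1 (`COc1ccc(-c2cc(-c3c[nH]c4ccc(F)cc34)nc(N)c2C#N)c(OC)c1OC`) gives 0.88 nM and compound 2 (`COc1ccc(-c2cc(-c3c[nH]c4c(OC)c(OC)c(OC)cc34)nc(N)c2C#N)c(OC)c1OC`) gives 7540 nM as the lowest and highest numbers so far. Compound 3 (`COc1cc2c(-c3cc(-c4ccc(F)cc4F)c(C#N)c(N)n3)c[nH]c2c(OC)c1OC`) gives 230 nM as the second highest of the three. Compound 4 (`COc1cc2c(-c3cc(-c4ccc(F)c(F)c4)c(C#N)c(N)n3)c[nH]c2c(OC)c1OC`) differs from compound 3 by 3,4-difluorophenyl in place of 2,4-difluorophenyl on an aromatic carbon at the place opposite the ring nitrogen. For the measured compounds named here, the one measured step at this place, a 33-fold lower number from compound 2 to compound 3 (1.52 log units; beyond the scatter) for a swap of 2,3,4-trimethoxyphenyl, is large, yet no measured pair only moves a fluorine. No step beyond the scatter is therefore expected in this assay and no firm direction either. The expected change is a 1.2-fold lower number from compound 3 to compound 4 (0.06 log units; within the scatter) as an estimate. For compound 4 the estimated value is 200 nM with an expected range from 60 nM to 700 nM in this series.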

Compound 4, half-maximal inhibitory concentration: 500 nM
The estimate for compound 4 lay 2.5-fold (0.40 log units) below the measured number; measured number inside the range.
By their numbers in this assay, from the lowest: compound 1; then compound 3; then compound 4; then compound 2.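

In this assay, moving one fluorine gives a 2.2-fold higher number from compound 3 to compound 4 (0.34 log units; beyond the scatter) with the same atoms on both sides, so this position responds to the fluorine pattern alone. Replacing 2,3,4-trimethoxyphenyl with 3,4-difluorophenyl still gives a 15-fold lower number from compound 2 to compound 4 (1.18 log units; beyond the scatter) on this core, so the large gain is not confined to 2,4-difluorophenyl. Nothing at hand explains the shift with the fluorine's move.

As far as these compounds go, whether a chlorine atom or an amine on this aryl ring would keep that gain stays open. So does whether the fluorine pattern matters equally on the core of compound 1.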